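Swapping Hydroxy for Azido on a Side Chain

A few compounds are considered here, and "the series" means these few. Any claim that something is new, unique, unknown or untested is made for them only; others in the source may bear on it.

Three compounds share one core: compound 1 `OCCNc1ccnc2cc(Cl)ccc12`, compound 2 `OCCCNc1ccnc2cc(Cl)ccc12` and compound 3 `O=C(N[C@@H](c1ccccc1)[C@@H](O)C(=O)NCCCNc1ccnc2cc(Cl)ccc12)c1ccccc1`, which has a more elaborate amide-bearing side chain. In an ADME assay on L6 cells (Rattus norvegicus) for cytotoxicity, read by resazurin assay, with a stated time of 70 h (a lower number here means a stronger inhibitor, a higher number a weaker inhibitor), compound 1 is entered as "not determined" (no result reported), and compound 2 is entered as "not determined" (no result reported), so neither has a number. Compound 2 therefore has no standing of its own on this scale. For the measured compounds named here, the only figure comes from compound 3, at 28300 nM.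

The change to follow is azido in place of hydroxy on a saturated chain carbon, three bonds along the chain from a nitrogen on an aromatic ring. It gives compound 4 `[N-]=[N+]=NCCCNc1ccnc2cc(Cl)ccc12`. Going by the values given here, with no measured pair to show what such a swap does, any forecast is tentative. In this assay no step beyond the scatter is expected from this change, and neither direction is favoured. Among the compounds with values here, the single anchor is compound 3 at 28300 nM, although its side chain is very different. For compound 4 the estimated value is 40000 nM, with an expected range from 10000 nM to 150000 nM.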

Compound 4, half-maximal inhibitory concentration: 9480 nM
Beside the measured number, compound 4's estimate is 4.2-fold (0.63 log units) above it; the measured number lies below the stated range.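

Compound 2 has no single number to set against compound 4 at 9480 nM, so no step can be read between them. The compounds shown leave open what swapping hydroxy for azido does in this assay. Nothing available explains the value of compound 4.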